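From pyridin-2-yl to 1H-imidazol-2-yl on a shared core

A few compounds are considered here, and "the series" means these few. Any claim that something is new, unique, unknown or untested is made for them only; others in the source may bear on it.

In a physicochemical assay for solubility, in phosphate buffer, with a stated time of 18 h (on this read-out lower numbers stand for lower solubility and higher numbers for higher solubility), compound 1 `CC(C)(C)c1nc(C2CCCC2)c2c(N)c(C#N)c(N)nc2n1`, which carries cyclopentyl on an aromatic carbon, is reported only as a limit, < 1000 nM.

The other two compounds carry an aromatic ring at that carbon and return true numbers. Compound 2 `CC(C)(C)c1nc(-c2cccs2)c2c(N)c(C#N)c(N)nc2n1`, with thiophen-2-yl, gives 56000 nM, and compound 3 `CC(C)(C)c1nc(-c2ccccn2)c2c(N)c(C#N)c(N)nc2n1`, with pyridin-2-yl, gives 87000 nM. Compound 3 therefore stands level with compound 2, as the step between them shows: a 1.6-fold higher number from compound 2 to compound 3 (0.19 log units; within the scatter).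

The next compound, compound 4 `CC(C)(C)c1nc(-c2ncc[nH]2)c2c(N)c(C#N)c(N)nc2n1`, has 1H-imidazol-2-yl in place of pyridin-2-yl on an aromatic carbon, next to the ring nitrogen: 1H-imidazol-2-yl in place of pyridin-2-yl on an aromatic carbon.

Two measured steps away from cyclopentyl were large, an at least 56-fold higher number from compound 1 to compound 2 (1.74 log units; beyond the scatter) and an at least 87-fold higher number from compound 1 to compound 3 (1.93 log units; beyond the scatter), but neither replaces one aromatic ring with another. Among the measured compounds shown here, the closest precedent for the new change is the exchange between thiophen-2-yl and pyridin-2-yl, which stayed within the scatter. It is a single pair, so the expectation is loose: no step beyond the scatter is expected in this assay, in either direction.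

The estimated step is a 1.2-fold lower number from compound 3 to compound 4 (0.09 log units; within the scatter).

For compound 4 the expected value is 70000 nM, with an estimated range of 20000 nM to 200000 nM.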

Compound 4, solubility: < 1000 nM
Compound 4: a limit, no number; the forecaster's own chance of this, stated with the estimate: 10%; at least 70-fold (1.84 log units) between middle value and limit.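

In this assay, the exchange of one aromatic ring for another at this carbon, which had stayed within the scatter between compound 2 and compound 3, now produces large steps: an at least 87-fold lower number from compound 3 to compound 4 (1.93 log units; beyond the scatter), and an at least 56-fold lower number from compound 2 to compound 4 (1.74 log units; beyond the scatter). An aromatic ring here is therefore not enough on its own to keep the number high, since compound 2 and compound 3 fit that pattern and compound 4 goes against it. Compound 4 is reported only as a limit, the same one as compound 1, so the step between those two cannot be read: the limit of < 1000 nM in this assay, at which 2 of the 4 values shown sit.

The compounds shown leave open whether the large steps follow the one hydrogen-bond donor that 1H-imidazol-2-yl brings, the five-membered ring with two hetero atoms, or both together. A 1-methylimidazol-2-yl group, with a methyl on the ring nitrogen that carries the hydrogen, or an oxazol-2-yl group would bear on that question, and the limit itself gives no number for compound 4.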